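Hydroxy for methoxy in a weakly active series

The compounds below may be only part of what the source reports. "The series", "measured", "known", "first", "only" and "open" are said of these compounds alone.

In a functional assay on KYSE-410 cells (Homo sapiens) for antiproliferative activity, read by MTT assay, with a stated time of 72 h (on this read-out lower numbers stand for stronger inhibition and higher numbers for weaker inhibition), compound 1 `O=C(Nc1cc(F)cc(F)c1)c1cc(=O)[nH]c2cc(C(F)(F)F)ccc12` gives 17900 nM. Compound 2 `COc1ccc2c(C(=O)Nc3cc(F)cc(F)c3)cc(=O)[nH]c2c1` gives > 20000 nM, which is a limit and not a number, and so it stands at the limit of > 20000 nM in this assay, at which 1 of the 2 values shown sits. Compound 3 `O=C(Nc1cc(F)cc(F)c1)c1cc(=O)[nH]c2cc(O)ccc12` differs from it by hydrogen in place of methyl on an oxygen on an aromatic ring, that is, methoxy to hydroxy. For the measured compounds named here, the one measured step bearing on this is an at least 1.1-fold higher number from compound 1 to compound 2 (0.04 log units; that floor lies within the scatter), so no shift beyond the scatter is expected in this assay. The expected change is a number no higher from compound 2 to compound 3 (the limit leaves the size open). Compound 3 is estimated at 20000 nM, within an expected range of 9000 nM to 40000 nM.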

Compound 3, half-maximal inhibitory concentration: > 20000 nM
Compound 3: a limit, no number (the forecaster's own chance of this, stated with the estimate: 65%); the middle value lies on the limit itself.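

Hydroxy on this aromatic ring leaves compound 3 in this assay with a limit and not a number, as methoxy did for compound 2, so the step between these two cannot be read. Hydroxy in place of trifluoromethyl gives an at least 1.1-fold higher number from compound 1 to compound 3 (0.04 log units; that floor lies within the scatter). A free hydroxy therefore brings no readable gain over methoxy, and the values gather at one limit: the limit of > 20000 nM in this assay, at which 2 of the 3 values shown sit.

On these data alone, whether an amine or a carboxylic acid on this aromatic carbon would give a measurable number stays open. As far as these compounds go, how far compound 2 and compound 3 lie past their limit also stays open.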